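Swapping the sulfonamide amine on compound 2

A few compounds are considered here, and "the series" means these few. Any claim that something is new, unique, unknown or untested is made for them only; others in the source may bear on it.

- Compound 1 `CCOc1ccc(S(=O)(=O)N(C)C(C)C)cc1-c1ncc(C(=O)O)c(=O)[nH]1`: > 10 mg/kg, a limit of the assay and not a number
- Compound 2 `CCOC(=O)c1cnc(-c2cc(S(=O)(=O)N(CC)CC)ccc2OCC)[nH]c1=O`: 10 mg/kg

Going by the values given here, in a functional assay on the whole organism (strain Sprague-Dawley) for inhibition, with Rattus norvegicus as the target, with a stated time of 10 min (a higher number here means that more compound is needed for the effect, a lower number that less compound is needed), compound 2 holds the only true number so far. Compound 3 `CCOC(=O)c1cnc(-c2cc(S(=O)(=O)N(C)C(C)C)ccc2OCC)[nH]c1=O` has the same atoms as compound 2, joined differently: isopropyl(methyl)amino in place of diethylamino on a sulfonyl sulfur, with isopropyl(methyl)amino in place of diethylamino on a sulfonyl sulfur. Among the compounds with values here, no measured pair shows what this swap does in this assay, so no change beyond the usual scatter is expected. The expected no change at the digits printed from compound 2 to compound 3 (within the scatter) is therefore small. For compound 3 the estimated value is 10 mg/kg, with an expected range of 4 mg/kg to 25 mg/kg.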

Compound 3, dose for 50% inhibition: > 10 mg/kg
Compound 3 was reported as a limit; the forecaster's own chance of this, stated with the estimate: 40%; the middle value sits exactly at the limit.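

In this assay, isopropyl(methyl)amino in place of diethylamino on a sulfonyl sulfur gives a number no lower from compound 2 to compound 3 (the limit leaves the size open). This pair shows that, at this position, the swap brings no gain in this assay, and that a change with the same atoms is enough to move compound 3 to a limit rather than a number. The size of the step stays hidden because the readings stop at this point: the limit of > 10 mg/kg in this assay, at which 2 of the 3 values shown sit.

The step from compound 1 to compound 3 cannot be read, since both values are limits. On these data alone, whether piperidine or dimethylamino on the sulfonyl sulfur would lower the dose remains open.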